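The source may hold more compounds than are shown below. What is called first, only, known or untested is meant among the compounds shown, and "the series" means these compounds.

Compound 3 `Oc1cccc(-c2cc(-c3ccoc3)cc(-c3cccc(O)c3)n2)c1` carries two 3-hydroxyphenyl groups and a furan-3-yl group on the shared core. In a functional assay on T47D cells (Homo sapiens) for cytotoxicity, read by CCK-8 assay (on this read-out lower numbers stand for stronger inhibition and higher numbers for weaker inhibition), compound 3 gives 2590 nM, the lowest of the two numbers at hand. Compound 1 `Oc1cccc(-c2cc(-c3ccco3)cc(-c3cccc(O)c3)n2)c1` gives 3520 nM in this assay, and the step is a 1.4-fold lower number from compound 1 to compound 3 (0.13 log units; within the scatter). Compound 2 `Oc1cccc(-c2cc(-c3ccoc3)cc(-c3ccccc3O)n2)c1` reaches in this assay > 50000 nM, which is a limit and not a number (the limit of > 50000 nM in this assay, at which 1 of the 3 values shown sits). The other measured step is an at least 19-fold lower number from compound 2 to compound 3 (1.28 log units; beyond the scatter). Compound 4 `Oc1cccc(-c2cc(-c3cccnc3)cc(-c3cccc(O)c3)n2)c1` differs from compound 3 by pyridin-3-yl in place of furan-3-yl on an aromatic carbon. Neither measured step covers this change: the furan swap stayed within the scatter, and the hydroxyphenyl swap concerns another group. The expected step is therefore a 1.2-fold higher number from compound 3 to compound 4 (0.06 log units; within the scatter), nothing beyond the scatter. Compound 4 is estimated at 3000 nM, between 1000 nM and 9000 nM.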

Compound 4, half-maximal inhibitory concentration: > 50000 nM
Compound 4: only a limit was reported (the forecaster's own chance of this, stated with the estimate: 10%); middle value at least 16-fold (1.22 log units) from the limit.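

Among these compounds, at this position, opposite the ring nitrogen, the earlier compounds showed only a swap between two furans, which stayed within the scatter, whereas the ring on this carbon now proves to matter in this assay. Pyridin-3-yl in place of furan-3-yl gives an at least 19-fold higher number from compound 3 to compound 4 (1.28 log units; beyond the scatter), and in place of furan-2-yl it gives an at least 14-fold higher number from compound 1 to compound 4 (1.15 log units; beyond the scatter). Compound 4 has only a limit and not a number, so both steps give only their smallest possible size: the limit of > 50000 nM in this assay, at which 2 of the 4 values shown sit.

The compounds shown leave open whether the change follows from the ring nitrogen of pyridin-3-yl or from the six-membered ring itself. They also leave open how a phenyl or a thiophen-3-yl group on this carbon would compare with the furans.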